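Removing the fluoro group from compound 1

The compounds below may be only part of what the source reports. "The series", "measured", "known", "first", "only" and "open" are said of these compounds alone.

Measured in a functional assay on MM1.S cells (Homo sapiens) for cytotoxicity, read by MTT assay, with a stated time of 48 h; on this read-out lower numbers stand for stronger inhibition and higher numbers for weaker inhibition:
- compound 1 `Fc1ccccc1NN=C1C(Cl)=C(Cl)C(Cl)=C1Cl`: > 3000 nM
- compound 2 `CC(C)(C)C(=O)NN=C1C(Cl)=C(Cl)C(Cl)=C1Cl`: 2000 nM
- compound 3 `Cc1ccc(C(=O)N(N=C2C(Cl)=C(Cl)C(Cl)=C2Cl)C(=O)c2ccc(C)cc2)cc1`: 500 nM

Compound 1 stands at > 3000 nM, which is a limit of the assay and not a number. Compound 4 `ClC1=C(Cl)C(Cl)=C(Cl)C1=NNc1ccccc1` remains unmeasured. Its difference from compound 1 is hydrogen in place of fluoro on an aromatic carbon, ortho to a large group. Among the measured compounds shown here, no measured pair isolates this change. In this assay no step beyond the scatter is expected, and a limit is again possible for compound 4. The expected size of the change is a step that the limit leaves unreadable from compound 1 to compound 4. The estimate for compound 4 is 3500 nM, with an expected range from 1500 nM to 8000 nM.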

Compound 4, half-maximal inhibitory concentration: 2000 nM
Compound 4: the middle estimate sits 1.8-fold (0.24 log units) above what was measured, and the stated range covers the measured number.
By their numbers in this assay, from the lowest: compound 3; then compounds 2 and 4 (each within the scatter of the next). At a limit, above all of these: compound 1.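

In this assay, hydrogen in place of fluoro on an aromatic carbon, ortho to a large group, yields a readable number: compound 4 gives 2000 nM. The change brings an at least 1.5-fold lower number from compound 1 to compound 4 (0.17 log units; that floor lies within the scatter). Fluoro at this position therefore shows no measurable gain in this assay, but the full size of the step cannot be read past that floor: the limit of > 3000 nM in this assay, at which 1 of the 4 values shown sits.

From the compounds shown here alone, what an amine, a methoxy group or a methyl group on this aromatic carbon would do remains open.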